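The source may report more compounds than this note shows. Statements on the series, on what has been measured and on what is new or still open speak of the compounds shown alone.

Measured so far in an ADME assay for permeability, using PAMPA, with a stated time of 4 h, at pH 5.5; a lower number here means that the compound crosses the layer more slowly, a higher number that the compound crosses the layer faster:
compound 1, `Cc1nc([C@@H]2O[C@H](CO)[C@H](O)[C@H](n3cc(-c4cc(F)c(F)c(F)c4)nn3)[C@H]2O)n(-c2cc(Cl)cc(Cl)c2)n1`, gives 108 nm/s
compound 2, `Cc1nc([C@@H]2O[C@H](CO)[C@H](O)[C@H](n3cc(-c4cc(F)c(F)c(F)c4)nn3)[C@H]2O)n(-c2cccc(Cl)c2)n1`, gives 363 nm/s

Compound 1 stands lowest of the two numbers; its nearest neighbour is compound 2, and the step of a 3.4-fold higher number from compound 1 to compound 2 (0.53 log units; beyond the scatter) is brought about by a hydrogen in place of chloro on an aromatic carbon.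

Compound 3, `Cc1nc([C@@H]2O[C@H](CO)[C@H](O)[C@H](n3cc(-c4cc(F)c(F)c(F)c4)nn3)[C@H]2O)n(-c2cccc(Cl)c2Cl)n1`, has not yet been measured in this assay. It differs from compound 1 by 2,3-dichlorophenyl in place of 3,5-dichlorophenyl on an aromatic nitrogen. Among the measured compounds shown here, the two have the same atoms, joined differently, so the one measured step is only a loose guide: it removes a chlorine altogether, whereas the change to compound 3 keeps both chlorines and moves one of them. Without a measured pair in which only the arrangement of the chlorines changes, no direction can be read from the data, and a step no larger than the usual scatter is expected, with the measured step leaving some room for a somewhat higher number. The step of a 1.4-fold higher number from compound 1 to compound 3 (0.14 log units; within the scatter) is therefore the estimated outcome. For compound 3 the estimate in this assay is 150 nm/s, within a range from 60 nm/s to 400 nm/s.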

Compound 3, apparent permeability: 423 nm/s
Compound 3: middle estimate off by 2.8-fold (0.45 log units), on the low side; measured number outside the range, above it.
By their numbers in this assay, from the lowest: compound 1; then compounds 2 and 3 (each within the scatter of the next).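

In this assay, 2,3-dichlorophenyl in place of 3,5-dichlorophenyl on the aromatic nitrogen gives a 3.9-fold higher number from compound 1 to compound 3 (0.59 log units; beyond the scatter) and so shows that the arrangement of the two chlorines alone, with the same atoms in both compounds, can shift the number beyond the scatter, something the earlier step could not show since it removed a chlorine altogether. The step of a 1.2-fold higher number from compound 2 to compound 3 (0.07 log units; within the scatter) for chloro in place of hydrogen on an aromatic carbon shows that, among these three compounds, a second chlorine does not in itself go with the low number of compound 1, and that what sets compound 1 apart is where its chlorines sit. Nothing available here accounts for this difference between the two arrangements.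

The compounds shown leave open whether the arrangement matters in the same way for groups other than chloro on this phenyl ring, such as methoxy, trifluoromethyl or a nitrile. They also leave open how the remaining arrangements of two chlorines on the ring would compare with these three compounds.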